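A few compounds are considered here, and "the series" means these few. Any claim that something is new, unique, unknown or untested is made for them only; others in the source may bear on it.

Measured so far:
- Compound 1, `CCN(Cc1cccs1)C(=O)c1cc2cc(C)ccc2s1`: 1600 nM
- Compound 2, `CON(Cc1cccs1)C(=O)COc1ccc(C)cc1`: 10 nM
- Compound 3, `Cc1ccc2oc(C(=O)N(Cc3cccs3)c3ccn[nH]3)cc2c1`: 40 nM

These three compounds were tested in an assay on HEK293 cells for agonist activity at transient receptor potential cation channel subfamily M member 8 (Homo sapiens), read by fluorescence and calcium flux, with a stated time of 15 min; a higher number here means that more compound is needed for the effect, a lower number that less compound is needed. Among them compound 2 stands lowest, with 10 nM; the nearest is compound 3 at 40 nM, a gap beyond the usual scatter, and the furthest is compound 1 at 1600 nM, far beyond it. Compound 2 is thus the most potent of the three.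

Compound 4, `Cc1ccc(OCC(=O)N(Cc2cccs2)c2cnn(C)c2)cc1`, has not yet been measured. It differs from compound 2 in one place: 1-methyl-1H-pyrazol-4-yl in place of methoxy on an amide-type nitrogen. The aryloxyacetamide part of compound 2 is kept; only the group on the amide-type nitrogen is exchanged. For the measured compounds named here, no measured pair in this set shows exactly this change, so its size is not known from the data. Compound 3 carries a related five-membered aromatic ring on its amide nitrogen and still gives 40 nM, which suggests such a ring is tolerated. Compound 4 is therefore expected to remain potent, with a step of a 3.0-fold higher number from compound 2 to compound 4 (0.48 log units; beyond the scatter) that is small and most likely toward a somewhat higher number. The estimate for compound 4 in this assay is 30 nM, within a range from 8 nM to 120 nM.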

Compound 4, half-maximal effective concentration: 63000 nM
Compound 4: the middle estimate sits 2100-fold (3.32 log units) below what was measured; measured number outside the range, above it.
By their numbers in this assay, from the lowest: compound 2; then compound 3; then compound 1; then compound 4.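

In this assay, this one exchange on an amide-type nitrogen, 1-methyl-1H-pyrazol-4-yl in place of methoxy, gives a 6300-fold higher number from compound 2 to compound 4 (3.80 log units; beyond the scatter), so this position of compound 2 is far from indifferent to what it carries. The earlier compounds shown here could not show this, since none of them forms a pair that differs only at this nitrogen. Nothing here explains why the step is so large, and the change itself swaps a chainlike group of two heavy atoms for a ring of six, so no single feature of it can be singled out.

As far as these compounds go, whether the loss comes with any ring at this place or with this particular ring stays open. Compounds carrying ethoxy, a plain methyl or a phenyl ring on the same nitrogen would help to separate these possibilities.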